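The source may hold more compounds than are shown below. What is called first, only, known or untested is meant among the compounds shown, and "the series" means these compounds.

Measured compounds in an assay on isolated protein for inhibition of Fatty-acid amide hydrolase 1 (Homo sapiens), with a stated time of 60 min; a higher number here means a weaker inhibitor, a lower number a stronger inhibitor:
- compound 1 `O=C(Nc1cccc2nonc12)N1CCN(Cc2cccc(Oc3ccc(Cl)cc3)c2)CC1` gives 28 nM
- compound 2 `Cc1nc2cc(NC(=O)N3CCN(Cc4cccc(Oc5ccc(Cl)cc5)c4)CC3)ccc2o1` gives 7.7 nM
- compound 3 `O=C(Nc1noc2cnccc12)N1CCN(Cc2cccc(Oc3ccc(Cl)cc3)c2)CC1` gives 0.5 nM

Compound 1 has the highest number of the three in this assay; compound 2 comes nearest with a 3.6-fold lower number from compound 1 to compound 2 (0.56 log units; beyond the scatter), and compound 3 is furthest with a 56-fold lower number from compound 1 to compound 3 (1.75 log units; beyond the scatter). Between the two others, a 15-fold lower number from compound 2 to compound 3 (1.19 log units; beyond the scatter) separates them clearly.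

Compound 4 `O=C(Nc1cn2ccccc2n1)N1CCN(Cc2cccc(Oc3ccc(Cl)cc3)c2)CC1` differs from compound 1 on the amide-type nitrogen whose other neighbour is the carbonyl carbon: a group of 9 heavy atoms (7 carbon, 2 nitrogen; one five-membered aromatic ring with 2 hetero atoms, one six-membered aromatic ring with 1 hetero atom) in place of a group of 9 heavy atoms (6 carbon, 2 nitrogen, 1 oxygen; one five-membered aromatic ring with 3 hetero atoms, one six-membered aromatic ring of carbon only), on an amide-type nitrogen.

Both measured steps that start from compound 1 replace the same group on the same nitrogen and both lower the number, one modestly and one strongly. Compound 4 keeps the same atom count as the group that leaves and, like compound 3, brings a six-membered aromatic ring with one hetero atom, so a lower number than compound 1 is expected, of a size between those two steps. The estimate for compound 4 is 5 nM, with a range of 1 nM to 30 nM, corresponding to a 5.6-fold lower number from compound 1 to compound 4 (0.75 log units; beyond the scatter).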

Compound 4, half-maximal inhibitory concentration: > 10000 nM
Compound 4: only a limit was reported (the forecaster's own chance of this, stated with the estimate: 2%); middle value at least 2000-fold (3.30 log units) away from the limit.
By their numbers in this assay, from the lowest: compound 3; then compound 2; then compound 1. At a limit, above all of these: compound 4.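

Compound 4 can be read only as a limit in this assay: the limit of > 10000 nM in this assay, at which 1 of the 4 values shown sits. Against its measured neighbours the steps are an at least 350-fold higher number from compound 1 to compound 4 (2.55 log units; beyond the scatter), an at least 1200-fold higher number from compound 2 to compound 4 (3.11 log units; beyond the scatter) and an at least 20000-fold higher number from compound 3 to compound 4 (4.30 log units; beyond the scatter), so this amide-type nitrogen does not accept every group built from a five-membered and a six-membered aromatic ring. Compound 3 and compound 4 both carry a six-membered aromatic ring with 1 hetero atom and the same heavy-atom count, so neither feature alone keeps the number low, and among these four compounds only compound 4 has a group without oxygen.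

As far as these compounds go, whether the oxygen itself or the arrangement of the ring atoms separates compound 4 from the others remains open. A group with sulfur in place of that oxygen, or a plain phenyl on the same nitrogen, would help to separate these two readings.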